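Ethylamino for pyrrolidin-1-yl at the assay limit

The source may hold more compounds than are shown below. What is called first, only, known or untested is meant among the compounds shown, and "the series" means these compounds.

Measured in an ADME assay on Huh7.5.1 cells (Homo sapiens) for cytotoxicity, read by WST assay, with a stated time of 48 h; on this read-out higher numbers stand for lower toxicity in this test and lower numbers for higher toxicity in this test:
- Compound 1 `Cc1c(-c2ccc(Cc3ccc(S(=N)(=O)C(F)(F)F)cc3)cc2)[nH]c2cccc(F)c2c1=O` gives > 10000 nM (a limit)
- Compound 2 `Cc1c(-c2ccc(Oc3ccc(N4CCCC4)cc3)c(F)c2)[nH]c2cccc(F)c2c1=O` gives > 10000 nM (a limit)

Compound 2 has no number in this assay, only the limit > 10000 nM. Among the measured compounds shown here, the two measured compounds share (the limit of > 10000 nM in this assay, at which 2 of the 2 values shown sit), so no step between them can be read. Compound 3 `CCNc1ccc(Oc2ccc(-c3[nH]c4cccc(F)c4c(=O)c3C)cc2F)cc1` carries ethylamino in place of pyrrolidin-1-yl on an aromatic carbon, para to a large group, and otherwise matches compound 2 (ethylamino in place of pyrrolidin-1-yl on an aromatic carbon). For the measured compounds named here, no measured step shows what such a change does, so no step beyond the scatter, in either direction, is expected in this assay. That expectation rests on compound 2 and its limit of > 10000 nM. The expected change is a step that the limit leaves unreadable from compound 2 to compound 3. Compound 3 is estimated at 12000 nM, with an expected range from 4000 nM to 30000 nM.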

Compound 3, half-maximal cytotoxic concentration: > 10000 nM
Compound 3 gave a limit, no number (the forecaster's own chance of this, stated with the estimate: 75%); the middle value does not contradict the limit.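

No step from compound 2 to compound 3 can be read in this assay, because both compounds give only a limit: the limit of > 10000 nM in this assay, at which 3 of the 3 values shown sit.

The compounds shown leave open what ethylamino in place of pyrrolidin-1-yl does in this assay, and at what concentration any of the three compounds turns toxic.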